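A few compounds are considered here, and "the series" means these few. Any claim that something is new, unique, unknown or untested is made for them only; others in the source may bear on it.

Measured so far in an ADME assay on L02 cells (Homo sapiens) for cytotoxicity, read by MTT assay, with a stated time of 72 h; on this read-out higher numbers stand for weaker inhibition and lower numbers for stronger inhibition:
- compound 1 `Cc1ccccc1NC(=O)CCC(=O)OCCCCCCSc1ccc([N+](=O)[O-])c2nonc12`: 9490 nM
- compound 2 `COc1ccccc1NC(=O)CCC(=O)OCCCCCCSc1ccc([N+](=O)[O-])c2nonc12`: 4490 nM
- compound 3 `O=C(CCC(=O)OCCCCCCSc1ccc([N+](=O)[O-])c2nonc12)Nc1ccc(C(F)(F)F)cc1`: 5010 nM

These three compounds share the same core and differ only in the aromatic group on the amide-type nitrogen. Compound 2 stands at 4490 nM, clearly apart from only one of the other two. The change to it is a 2.1-fold lower number from compound 1 to compound 2 (0.33 log units; beyond the scatter), a modest step, while a 1.1-fold higher number from compound 2 to compound 3 (0.05 log units; within the scatter) does not separate the pair.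

The next compound is compound 4 `O=C(CCC(=O)OCCCCCCSc1ccc([N+](=O)[O-])c2nonc12)Nc1ccc(F)c(Cl)c1`. Its change is 3-chloro-4-fluorophenyl in place of 2-methoxyphenyl on an amide-type nitrogen. In words, 3-chloro-4-fluorophenyl stands in place of 2-methoxyphenyl on an amide-type nitrogen.

Among the measured compounds shown here, the closest precedent is compound 3, which replaces the same group, and a 1.1-fold higher number from compound 2 to compound 3 (0.05 log units; within the scatter) is very small. The other swap of this group, a 1.9-fold lower number from compound 1 to compound 3 (0.28 log units; within the scatter), also stays within the scatter. For the measured compounds named here, every change at this place so far has been small, although no measured compound carries this exact group. In this assay, therefore, no step beyond the scatter is expected, in either direction.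

What is expected is a 1.1-fold higher number from compound 2 to compound 4 (0.05 log units; within the scatter). Compound 4 is estimated at 5000 nM, with an expected range from 2300 nM to 11000 nM.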

Compound 4, half-maximal inhibitory concentration: 4570 nM
The estimate for compound 4 lay 1.1-fold (0.04 log units) above the measured number; low and high end bracket the measured number.
By their numbers in this assay, from the lowest: compounds 2, 4, 3 and 1 (each within the scatter of the next, the first and the last beyond it).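

In this assay, 3-chloro-4-fluorophenyl on the amide-type nitrogen cannot be told apart from 2-methoxyphenyl (a 1.0-fold higher number from compound 2 to compound 4 (0.01 log units; within the scatter)), even though the entering group counts 0 hydrogen-bond acceptors against 1 and carries fluorine and chlorine instead of oxygen. It also cannot be told apart from 4-(trifluoromethyl)phenyl (a 1.1-fold lower number from compound 3 to compound 4 (0.04 log units; within the scatter)), so compounds 2, 3 and 4 now form a set of three differently substituted rings, all within the scatter of one another, while compound 1 is separated from compound 4 by a modest step (a 2.1-fold lower number from compound 1 to compound 4 (0.32 log units; beyond the scatter)) as it is from compound 2, although compound 3, within the scatter of compound 1, goes against any clean split. Nothing available gives a reason for this narrow spread of numbers.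

The compounds shown all carry a substituted phenyl ring at this place, so it remains open whether the numbers would stay this close with a ring bearing an amine or a carboxylic acid. A plain alkyl chain on the amide-type nitrogen in place of the ring is equally untested here.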